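Aryl ether variation on the pyridyl-pyrimidine series

The source may report more compounds than this note shows. Statements on the series, on what has been measured and on what is new or still open speak of the compounds shown alone.

Two compounds of this series have numbers in a functional assay on cells for antagonist activity at Free fatty acid receptor 1 (Homo sapiens), read by TR-FRET and inositol phosphate accumulation, with a stated time of 2 h; a higher number here means a weaker inhibitor, a lower number a stronger inhibitor. Compound 1 `Cc1cc(COc2ccccc2Cl)nc(-c2ccccn2)n1` gives 316 nM and holds the lowest number of the two. Compound 2 `Cc1cc(COc2cccc(C#N)c2)nc(-c2ccccn2)n1` gives 2510 nM; the gap between compound 1 and compound 2 is beyond the scatter, and compound 1 is the stronger inhibitor of the pair. Among the measured compounds shown here, no single-change step between measured compounds is available, so the series so far shows only that a change in the aryl ether is enough to move the number a good deal.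

Compound 3 `Cc1cc(COc2ccc(F)cc2)nc(-c2ccccn2)n1` is not yet measured. It differs from compound 1 in one place: 4-fluorophenyl in place of 2-chlorophenyl on an oxygen on a saturated carbon. For the measured compounds named here, the step from compound 1 to compound 3 is expected to be modest and toward a weaker inhibitor, near the edge of the scatter, given that the only comparison on record, compound 2 at 2510 nM, also sits above compound 1. For compound 3 the estimated value is 800 nM, with a range from 250 nM to 2500 nM. The expected step is a 2.5-fold higher number from compound 1 to compound 3 (0.40 log units; beyond the scatter).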

Compound 3, half-maximal inhibitory concentration in the Free fatty acid receptor 1 assay: 631 nM
Beside the measured number, compound 3's estimate is 1.3-fold (0.10 log units) above it; the measured number falls inside the stated range.
By their numbers in the Free fatty acid receptor 1 assay, from the lowest: compounds 1 and 3 (each within the scatter of the next); then compound 2.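

Among the compounds shown here, in the Free fatty acid receptor 1 assay, 4-fluorophenyl in place of 2-chlorophenyl on an oxygen on a saturated carbon gives the first single-change step, a 2.0-fold higher number from compound 1 to compound 3 (0.30 log units; within the scatter), so this exchange of one halogenated phenyl group for another leaves no readable difference in the number. In a physicochemical assay for lipophilicity, at pH 7.4 (on this read-out higher numbers stand for higher lipophilicity and lower numbers for lower lipophilicity), the same exchange does register, as a number 0.40 log units lower from compound 1 to compound 3 (beyond the scatter). In the physicochemical assay compound 1 gives 3.4 and compound 3 gives 3. The two read-outs therefore part at this position, with lipophilicity lower for compound 3 while its number in the Free fatty acid receptor 1 assay stays within the scatter of that of compound 1, and the series thus has a change that separates the two read-outs: the measured distribution coefficient of compound 1, 3.4, and of compound 3, 3, a number 0.40 log units lower (beyond the scatter)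

The step changes both the halogen and its place on the phenyl ring, so it cannot tell which of the two accounts for the lipophilicity difference; 2-fluorophenyl and 4-chlorophenyl would separate them. The compounds shown also leave open how the number and the lipophilicity respond to an amine or a carboxylic acid on the aryl ring, and whether any group at this position gives a number clearly lower than that of compound 1.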